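The compounds below may be only part of what the source reports. "The series", "measured", "known", "first", "only" and "open" are said of these compounds alone.

In an ADME assay on HEK293 cells (Homo sapiens) for cytotoxicity, read by MTT assay, with a stated time of 72 h (on this read-out higher numbers stand for weaker inhibition and lower numbers for stronger inhibition), compound 3 `COc1ccc(C2=C(c3cc(OC)c(OC)c(OC)c3)C(=O)C(O)C2)cc1Cl` gives only a limit of the assay and not a number, > 100 ug/mL. Compound 4 `COc1ccc(C2=C(c3cc(OC)c(OC)c(OC)c3)C(=O)C(OC(C)=O)C2)cc1Cl` differs from it in one place: acetyl in place of hydrogen on an oxygen on a saturated carbon, which reads as hydroxy to acetoxy.

Among the compounds with values here, no measured pair makes this exact change, so the nearest evidence comes from two compounds that already carry the acetoxy group. Compound 1 `COc1ccc(C2=C(c3cc(OC)c(OC)c(OC)c3)C(=O)C(OC(C)=O)C2)cc1OC(C)C` also gives only a limit, > 100 ug/mL. Compound 2 `COc1ccc(C2=C(c3cc(OC)c(OC)c(OC)c3)C(=O)C(OC(C)=O)C2)cc1F` gives a true number, 59 ug/mL. Within the data shown here, the one measured step is an at least 1.6-fold lower number from compound 1 to compound 2 (0.22 log units; that floor lies within the scatter). That step lies at a different place on the shared core, so it does not measure the change from hydroxy to acetoxy. It offers only a weak guide to size.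

A small move toward lower numbers is therefore expected, possibly no larger than the scatter, and the expected step is an at least 1.2-fold lower number from compound 3 to compound 4 (0.09 log units; that floor lies within the scatter). For compound 4 the estimated value is 80 ug/mL, with an expected range from 35 ug/mL to 180 ug/mL.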

Compound 4, half-maximal inhibitory concentration: 60 ug/mL
Compound 4: the middle estimate sits 1.3-fold (0.12 log units) above what was measured; measured number inside the range.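

In this assay, on these data alone, the step of an at least 1.6-fold lower number from compound 3 to compound 4 (0.22 log units; that floor lies within the scatter) is only a floor that stays within the scatter, so the true size of hydroxy to acetoxy on this saturated carbon remains unknown, because that step rests on a limit: the limit of > 100 ug/mL in this assay, at which 2 of the 4 values shown sit. On the aromatic carbon, chloro in place of fluoro gives a 1.0-fold higher number from compound 2 to compound 4 (0.01 log units; within the scatter) and so, with the acetoxy group present, these two groups cannot be told apart here. Chloro in place of isopropoxy gives an at least 1.6-fold lower number from compound 1 to compound 4 (0.22 log units; that floor lies within the scatter) and so shows the same floor as the step to compound 2, again within the scatter.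

As far as these compounds go, how far the hydroxy compound truly lies from its acetoxy partner remains open. Also open, from the compounds shown here alone, is what a longer ester chain or an amine in place of the acetoxy group would give.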